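The source may hold more compounds than are shown below. What is called first, only, known or untested is meant among the compounds shown, and "the series" means these compounds.

Measured so far:
compound 1, `COc1ccccc1NC(=O)Nc1cccc(CNc2ncnc3ccccc23)c1`: 17500 nM
compound 2, `CC(C)(C)c1ccc(NC(=O)Nc2cccc(CNc3ncnc4ccccc34)c2)cc1`: 17000 nM

In a functional assay on HepG2 cells (Homo sapiens) for antiproliferative activity, read by MTT assay (a lower number here means a stronger inhibitor, a higher number a weaker inhibitor), compound 1 gives 17500 nM and compound 2 gives 17000 nM. The step of a 1.0-fold lower number from compound 1 to compound 2 (0.01 log units; within the scatter) is within the scatter, so the two numbers cannot be told apart on this evidence, and compound 2 stands level with compound 1.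

Compound 3, `O=C(Nc1ccc(F)cc1)Nc1cccc(CNc2ncnc3ccccc23)c1`, carries the change (fluoro in place of tert-butyl on an aromatic carbon); cut one bond further out, this reads 4-(tert-butyl)phenyl to 4-fluorophenyl. Within the data shown here, the only step that bears on it is a 1.0-fold lower number from compound 1 to compound 2 (0.01 log units; within the scatter), where exchanging the aryl group on the same amide-type nitrogen moved nothing beyond the scatter. On that basis the expected step of a 1.1-fold higher number from compound 2 to compound 3 (0.02 log units; within the scatter) is none beyond the scatter. Compound 3 is therefore estimated at 18000 nM in this assay, with a range from 8000 nM to 40000 nM.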

Compound 3, half-maximal inhibitory concentration: 41500 nM
Compound 3: middle estimate off by 2.3-fold (0.36 log units), on the low side; measured number above the stated range.
By their numbers in this assay, from the lowest: compounds 2 and 1 (each within the scatter of the next); then compound 3.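

In this assay, among these compounds, the aryl group on this amide-type nitrogen is no longer silent: fluoro in place of tert-butyl on the aromatic carbon gives a 2.4-fold higher number from compound 2 to compound 3 (0.39 log units; beyond the scatter), whereas the first exchange on this nitrogen stayed within the scatter. 4-Fluorophenyl in place of 2-methoxyphenyl gives a 2.4-fold higher number from compound 1 to compound 3 (0.38 log units; beyond the scatter), so compound 3 is the weakest of the three, while compound 1 and compound 2 stand level despite carrying different aryl groups. No measurement shown explains this rise in the number.

The three compounds do not show whether the step follows from the fluoro group entering or the tert-butyl group leaving. Unsubstituted phenyl, 4-chlorophenyl or 4-methoxyphenyl on the same nitrogen would separate these readings, and the effect of changes elsewhere on the shared core remains open.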